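The source may report more compounds than this note shows. Statements on the series, on what has been measured and on what is new or still open speak of the compounds shown alone.

Working notes on the aryl variation at the shared core. Among the measured compounds shown here, compound 1 `CCCn1ccc2cc(-c3cccnc3)cc(Cl)c2c1=O` carries a pyridin-3-yl ring, and in a functional assay on CHO cells for agonist activity at metabotropic glutamate receptor 2 (Homo sapiens), read by GTPgammaS binding (a higher number here means a larger maximal response, a lower number a smaller maximal response), compound 1 gives 83%, the highest of the three values measured so far. Compound 2 `CCCn1ccc2cc(-c3cncnc3)cc(Cl)c2c1=O` has pyrimidin-5-yl in its place and gives 28%; compound 3 `CCCn1ccc2cc(-c3cn[nH]c3)cc(Cl)c2c1=O` has 1H-pyrazol-4-yl there and gives 65%. The measured steps are a number 55 percentage points lower from compound 1 to compound 2 (beyond the scatter), a number 18 percentage points lower from compound 1 to compound 3 (beyond the scatter) and a number 37 percentage points higher from compound 2 to compound 3 (beyond the scatter). Every one of them exchanges the ring itself.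

Compound 4 `CCCn1ccc2cc(-c3ccc(N(C)C)nc3)cc(Cl)c2c1=O` keeps the pyridin-3-yl ring of compound 1 and differs from it in that (dimethylamino in place of hydrogen on an aromatic carbon), the new group sitting on an aromatic carbon of a six-membered aromatic ring with one nitrogen, next to the ring nitrogen and para to a large group. For the measured compounds named here, no measured step bears directly on a substituent added to a retained ring; the ring exchanges only show that the maximal response in this assay is sensitive to what stands at this position. A small downward step, or none beyond the scatter, is therefore expected, a number 8 percentage points lower from compound 1 to compound 4 (within the scatter). For compound 4 the value in this assay is estimated at 75%, within 50% to 95%.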

Compound 4, largest response reached (Emax), in percent of the reference or control that the assay uses: 85%
For compound 4 the middle estimate is 10 percentage points below the measured one; the measured number falls inside the stated range.
By their numbers in this assay, from the lowest: compound 2; then compound 3; then compounds 1 and 4 (each within the scatter of the next).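

Dimethylamino on an aromatic carbon of the pyridin-3-yl ring, next to the ring nitrogen and para to a large group, leaves compound 4 indistinguishable from its parent in this assay, with a number 2 percentage points higher from compound 1 to compound 4 (within the scatter) and no loss of maximal response beyond the scatter. The three ring exchanges all gave steps beyond the scatter, so among the compounds shown, replacing the ring has shifted the response while this one substituent on the retained ring has not. Nothing available here accounts for this result.

From the compounds shown here alone, it remains open whether other groups on the same carbon, such as a primary amine, a methoxy group, a morpholine or a carboxylic acid, would be accommodated equally well. Also open, going by these compounds, is whether dimethylamino would have any effect on the pyrimidin-5-yl ring of compound 2 or the 1H-pyrazol-4-yl ring of compound 3 .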